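Carboxy on compound 1: expected shift in tolerated concentration

The compounds below may be only part of what the source reports. "The series", "measured", "known", "first", "only" and "open" are said of these compounds alone.

Among the compounds with values here, in an ADME assay on HEp-2 cells (Homo sapiens) for cytotoxicity (a lower number here means that less compound is tolerated, a higher number that more compound is tolerated), compound 1 `C=C(C)n1c(=O)n(Cc2nc3ccccc3n2CCC(C)C)c2ccccc21` gives 24600 nM as the higher of the two numbers so far. Compound 2 `CC(C)CCn1c(Cn2c(=O)n(C(C)C)c3ccccc32)nc2c(CCCN)cccc21` gives 2340 nM and that gap lies beyond the scatter. Compound 3 `C=C(C)n1c(=O)n(Cc2nc3cc(C(=O)O)ccc3n2CCC(C)C)c2ccccc21` carries carboxy in place of hydrogen on an aromatic carbon of the core of compound 1 (carboxy in place of hydrogen on an aromatic carbon). Within the data shown here, no measured pair isolates this change, so the expectation is loose. In this assay the estimated 1.8-fold higher number from compound 1 to compound 3 (0.26 log units; within the scatter) is a modest one upward, toward more compound tolerated. For compound 3 the expected value is 45000 nM (range 15000 nM to 130000 nM).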

Compound 3, half-maximal cytotoxic concentration: 30000 nM
For compound 3 the middle estimate is 1.5-fold (0.18 log units) above the measured one; the range from low to high includes it.
By their numbers in this assay, from the lowest: compound 2; then compounds 1 and 3 (each within the scatter of the next).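

In this assay carboxy in place of hydrogen on an aromatic carbon of the core of compound 1 leaves the number within the scatter (a 1.2-fold higher number from compound 1 to compound 3 (0.09 log units; within the scatter)). Within the data shown here, this is the first pair that isolates one change, and it shows that this position carries carboxy with no change beyond the scatter in this read-out. No supporting measurement bears on this result. Still open, on these data alone, is whether a methyl ester or a primary amide on this aromatic carbon would give a similar number.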